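Compound 4 estimated from three close analogues

The source may hold more compounds than are shown below. What is called first, only, known or untested is meant among the compounds shown, and "the series" means these compounds.

Of the compounds shown here, three built on a shared core have been tested in a functional assay on MCF7 cells (Homo sapiens) for inhibition, read by MTT assay; a higher number here means a weaker inhibitor, a lower number a stronger inhibitor. Compound 1 `COc1cc2ncnc(Nc3ccc(NC(=O)c4cccc(C)c4)cc3)c2cc1OC` gives 13000 nM. Compound 2 `COc1cc2ncnc(Nc3ccc(NC(=O)c4ccc(C)cc4)cc3)c2cc1OC` gives 19000 nM, and compound 3 `COc1cc2ncnc(Nc3ccc(NC(=O)c4cccc(Cl)c4)cc3)c2cc1OC` gives 18000 nM. Compound 1 has the smallest number of the three, yet a 1.5-fold higher number from compound 1 to compound 2 (0.16 log units; within the scatter) and a 1.4-fold higher number from compound 1 to compound 3 (0.14 log units; within the scatter) both lie within the scatter, as does a 1.1-fold lower number from compound 2 to compound 3 (0.02 log units; within the scatter), so the three compounds are not separated by these data.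

Compound 4 `COc1cc2ncnc(Nc3ccc(NC(=O)c4ccc(I)cc4)cc3)c2cc1OC` has not yet been measured. It differs from compound 1 in one place: 4-iodophenyl in place of 3-methylphenyl on a carbonyl carbon. Among the measured compounds shown here, two measured steps bear on this change. The first, a 1.5-fold higher number from compound 1 to compound 2 (0.16 log units; within the scatter), exchanges a 3-methylphenyl for a 4-methylphenyl on the carbonyl carbon; the second, a 1.4-fold higher number from compound 1 to compound 3 (0.14 log units; within the scatter), exchanges a methyl for a chloro on an aromatic carbon. Neither moved the number beyond the scatter, so no step beyond the scatter is expected in this assay here either. The step from compound 1 is expected to be a 1.2-fold higher number from compound 1 to compound 4 (0.06 log units; within the scatter). Compound 4 is therefore estimated at 15000 nM, with a range from 6000 nM to 40000 nM.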

Compound 4, half-maximal inhibitory concentration: 48000 nM
The estimate for compound 4 lay 3.2-fold (0.51 log units) below the measured number; the measured number lies above the stated range.
By their numbers in this assay, from the lowest: compounds 1, 3 and 2 (each within the scatter of the next); then compound 4.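

In this assay, among the compounds shown here, 4-iodophenyl on the carbonyl carbon is the first group to move the number beyond the scatter, with a 3.7-fold higher number from compound 1 to compound 4 (0.57 log units; beyond the scatter) and a 2.7-fold higher number from compound 3 to compound 4 (0.43 log units; beyond the scatter) as the steps from the two 3-substituted phenyl compounds. The cleanest comparison is a 2.5-fold higher number from compound 2 to compound 4 (0.40 log units; beyond the scatter), so compound 4 stands apart from all three earlier compounds, which methyl and chloro had left unseparated. Nothing shown here explains this step.

The compounds shown leave open whether a bromo or a methoxy group in place of the iodo would give a number near that of compound 4 or near those of the earlier compounds. They also leave open how an amine or a carboxylic acid on that aromatic carbon would read in this assay.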